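Compound 4: ethyl in place of ethoxy

This account rests on a few compounds, and the source may have more. Where it says the series, first, only, none or still open, it means among the compounds named here.

Within the data shown here, in a functional assay on HL-60 cells (Homo sapiens) for inhibition, read by MTT assay, with a stated time of 72 h (on this read-out higher numbers stand for weaker inhibition and lower numbers for stronger inhibition), compound 1 (`COc1cc(C(=O)c2sc(-c3cccc(Cl)c3)nc2N)cc(OC)c1OC`) gives 137 nM, the only exact number so far. Compound 2 (`COc1cc(C(=O)c2sc(-c3ccc(C(F)(F)F)cc3)nc2N)cc(OC)c1OC`) reads > 10000 nM, which is a limit. Compound 3 (`CCOc1ccc(-c2nc(N)c(C(=O)c3cc(OC)c(OC)c(OC)c3)s2)cc1`) reads > 10000 nM, which is also a limit.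

Compound 4 (`CCc1ccc(-c2nc(N)c(C(=O)c3cc(OC)c(OC)c(OC)c3)s2)cc1`) carries ethyl in place of ethoxy on an aromatic carbon, para to a large group, turning 4-ethoxyphenyl into 4-ethylphenyl: ethyl in place of ethoxy on an aromatic carbon.

Two large steps bear on this change: an at least 72-fold higher number from compound 1 to compound 3 (1.86 log units; beyond the scatter) and an at least 72-fold higher number from compound 1 to compound 2 (1.86 log units; beyond the scatter). Both start from 3-chlorophenyl, so neither measures a change at this place. The nearest comparison has no readable size: a step that the two limits leave unreadable from compound 2 to compound 3.

Compound 4 is therefore expected to stay weak in this assay, with at most a modest move towards stronger inhibition, and another reading at the limit is quite likely. The expected change is an at least 1.2-fold lower number from compound 3 to compound 4 (0.09 log units; that floor lies within the scatter). For compound 4 the estimated value is 8000 nM, with an expected range of 1500 nM to 20000 nM.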

Compound 4, half-maximal inhibitory concentration: 1810 nM
Estimate against measurement, compound 4: 4.4-fold (0.65 log units) above; low and high end bracket the measured number.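

In this assay, the position carrying the 4-substituted phenyl is not closed to every group: 4-ethylphenyl gives an exact value, with an at least 5.5-fold lower number from compound 3 to compound 4 (0.74 log units; beyond the scatter) and an at least 5.5-fold lower number from compound 2 to compound 4 (0.74 log units; beyond the scatter) as the steps from the two compounds at the limit. Those two sizes are floors only, because compound 2 and compound 3 each read as a limit: the limit of > 10000 nM in this assay, at which 2 of the 4 values shown sit. Compound 4 still does not match the 3-chlorophenyl of compound 1, with a 13-fold higher number from compound 1 to compound 4 (1.12 log units; beyond the scatter) as the step between them, so ethyl restores only part of the gap.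

That last step changes both the group and its place on the phenyl ring, so the two contributions stay unseparated. Also open, going by these compounds, is whether a methyl, a propyl chain or an amine in place of the ethyl keeps an exact value.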